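Compound 4: benzoyl in place of trifluoromethyl

The source may report more compounds than this note shows. Statements on the series, on what has been measured and on what is new or still open speak of the compounds shown alone.

In a physicochemical assay for solubility, read by spectrophotometry (a higher number here means a more soluble compound, a lower number a less soluble compound), compound 1 `O=C(Nc1ccc(C(F)(F)F)cc1)c1cc(Cl)ccc1O` gives < 100000 nM, which is a limit of the assay and not a number. Compound 2 `O=C(Nc1ccc(C(F)(F)F)cc1)c1cc(Br)ccc1O` gives < 100000 nM, also a limit. Compound 3 `O=C(Nc1ccc(Cl)c(Cl)c1)c1cc(Br)ccc1O` gives < 100000 nM, again a limit. Going by the values given here, the series so far stands at the limit of < 100000 nM in this assay, at which 3 of the 3 values shown sit, so compound 1 has no exact value to serve as a starting point.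

Among the compounds with values here, the only measured single-place step is bromo in place of chloro on an aromatic carbon, and it reads a step that the two limits leave unreadable from compound 1 to compound 2. It therefore offers no size to carry forward, and it concerns a different group from the next change.

Compound 4 `O=C(c1ccccc1)c1ccc(NC(=O)c2cc(Cl)ccc2O)cc1` keeps the rest of the core of compound 1. The change is benzoyl in place of trifluoromethyl on an aromatic carbon, para to a large group. Within the data shown here, no measured step in this assay tests this exchange, so neither a size nor a direction can be drawn from the data.

A limit is expected again for compound 4, as for compound 3 at < 100000 nM. The expected step is a step that the limit leaves unreadable from compound 1 to compound 4, and it remains a loose estimate. If a number is reported, the estimate for compound 4 is 50000 nM, with an expected range from 10000 nM to 100000 nM.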

Compound 4, solubility: < 50000 nM
Compound 4 ended at the assay's limit; the forecaster's own chance of this, stated with the estimate: 90%; the middle value sits exactly at the limit.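

In this assay compound 4 gives < 50000 nM, a limit of the assay and not a number. Compound 1 gives < 100000 nM, also a limit. The step between compound 1 and compound 4 cannot be read from these two limits. The compounds shown leave open the size and direction of every change in the series: all four values are limits.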